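Lengthening the hydroxyalkyl chain of a carbonate prodrug

The source may report more compounds than this note shows. Statements on the series, on what has been measured and on what is new or still open speak of the compounds shown alone.

Of the compounds shown here, three sharing one core have been measured in an ADME assay on the whole organism (serum) with Homo sapiens as the target; a lower number here means that the compound disappears faster, a higher number that the compound lasts longer. Compound 1 `Cc1cn(C2CC(N=[N+]=[N-])C(COC(=O)OCCO)O2)c(=O)[nH]c1=O` carries a hydroxy two bonds along the chain from an oxygen next to a carbonyl group; in this assay compound 1 gives only a limit, < 0.0167 h. Compound 2 `Cc1cn(C2CC(N=[N+]=[N-])C(COC(=O)OCCCO)O2)c(=O)[nH]c1=O` gives 0.167 h. Compound 3 `Cc1cn(C2CC(N=[N+]=[N-])C(COC(=O)NCCCC(=O)OC(C)(C)C)O2)c(=O)[nH]c1=O` again gives only a limit in this assay, > 48 h. Among the three, compound 2 is therefore the only one with an actual number, the other two sitting at a limit.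

For the measured compounds named here, the one step between compounds that differ in a single place is an at least 10-fold higher number from compound 1 to compound 2 (1.00 log units; beyond the scatter), with compound 1 at the limit of < 0.0167 h in this assay, at which 1 of the 3 values shown sits.

Compound 4 `Cc1cn(C2CC(N=[N+]=[N-])C(COC(=O)OCCCCO)O2)c(=O)[nH]c1=O` is the next member of the series: compared with compound 2 the change is hydroxymethyl in place of hydroxy on a saturated chain carbon, three bonds along the chain from an oxygen next to a carbonyl group. Going by the values given here, this is the same kind of change as the one from compound 1 to compound 2, cut one bond further out, so the measured step is the only guide, and it points toward a longer half-life, though its true size is hidden by the limit at compound 1. A gain is expected, a 6.0-fold higher number from compound 2 to compound 4 (0.78 log units; beyond the scatter), smaller than the bound just seen. Compound 4 is therefore estimated to give 1 h in this assay, within a range from 0.3 h to 6 h.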

Compound 4, half-life: 0.5 h
Compound 4: the middle estimate sits 2.0-fold (0.30 log units) above what was measured; low and high end bracket the measured number.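

In this assay, for the compounds shown here, the move from 3-hydroxypropyl to 4-hydroxybutyl gives a 3.0-fold higher number from compound 2 to compound 4 (0.48 log units; beyond the scatter), and this is the first lengthening of the chain whose size can be read in full, since real numbers stand at both ends. It confirms the direction seen in the earlier step: among the three hydroxyalkyl carbonates, the half-life rises with each added carbon, and the whole extension amounts to an at least 29-fold higher number from compound 1 to compound 4 (1.47 log units; beyond the scatter). That overall step is only a lower bound, as compound 1 gives a limit and not a number: the limit of < 0.0167 h in this assay, at which 1 of the 4 values shown sits.

With only a bound for the first lengthening, the compounds shown cannot tell whether each added carbon brings a smaller gain than the one before, nor whether the rise would go on with a longer chain such as 5-hydroxypentyl. They also leave open how the half-life would respond if an amine or a carboxylic acid took the place of the hydroxy on the 4-hydroxybutyl chain.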